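Furan-2-yl in place of pyridin-4-yl: what to expect

The compounds below may be only part of what the source reports. "The series", "measured", "known", "first", "only" and "open" are said of these compounds alone.

Among the measured compounds shown here, in an ADME assay on SH-SY5Y cells (Homo sapiens) for cytotoxicity, read by sulforhodamine B assay, with a stated time of 72 h (on this read-out lower numbers stand for stronger inhibition and higher numbers for weaker inhibition), compound 2 (`O=C(NCc1ccncc1)C1CCN(Cc2ccccc2)CC1`) gives 3370 nM, the only true number so far. Compound 1 (`O=C(NCc1ccccn1)C1CCN(Cc2ccccc2)CC1`) reads > 100000 nM, which is a limit of the assay rather than a number. These two compounds differ only in having pyridin-2-yl or pyridin-4-yl on a saturated chain carbon bound to an amide-type nitrogen. That single measured step, an at least 29-fold lower number from compound 1 to compound 2 (1.47 log units; beyond the scatter), is large, so this part of the molecule clearly matters.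

Compound 3 (`O=C(NCc1ccco1)C1CCN(Cc2ccccc2)CC1`) changes the same place: furan-2-yl in place of pyridin-4-yl on a saturated chain carbon bound to an amide-type nitrogen. In words, furan-2-yl takes the place of pyridin-4-yl. For the measured compounds named here, only one measured step bears on this, so the direction is uncertain. The expected step, leaning towards weaker inhibition in this assay, is a 4.5-fold higher number from compound 2 to compound 3 (0.65 log units; beyond the scatter). For compound 3 the estimated value is 15000 nM, with an expected range of 3000 nM to 80000 nM.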

Compound 3, half-maximal inhibitory concentration: > 100000 nM
Compound 3: a limit, no number (the forecaster's own chance of this, stated with the estimate: 25%); middle value at least 6.6-fold (0.82 log units) from the limit.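

In this assay, replacing pyridin-4-yl with furan-2-yl gives an at least 29-fold higher number from compound 2 to compound 3 (1.47 log units; beyond the scatter), so a large step at this position is no longer tied to pyridin-2-yl alone. Among the three compounds shown, only compound 2, with pyridin-4-yl, gives a true number, while the other two replacement groups, one six-membered and one five-membered, both end at a limit of the assay. The step between compound 1 and compound 3 cannot be read, since both compounds sit at that same limit: the limit of > 100000 nM in this assay, at which 2 of the 3 values shown sit.

Going by these compounds, how far compound 1 and compound 3 really lie from each other remains unknown. On these data alone, it also remains open whether a plain phenyl ring, pyridin-3-yl or a longer chain on the amide-type nitrogen would give a true number in this assay.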